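Trimming the Long Chain of Compound 1

A few compounds are considered here, and "the series" means these few. Any claim that something is new, unique, unknown or untested is made for them only; others in the source may bear on it.

Going by the values given here, in a functional assay on MCF7 cells (Homo sapiens) for antiproliferative activity, read by MTT assay (a lower number here means a stronger inhibitor, a higher number a weaker inhibitor), compound 1 `CCCCCCCCCCCCCCCC1(O)CC(=O)c2c(O)cc(O)cc2O1` gives 17500 nM as the only actual number so far. Compound 2 `CCCC/C=C\CCCCCCCCCc1cc(=O)c2c(O)cc(OCOC)cc2o1` shows > 67200 nM in this assay and this value is only a limit. Compound 3 `CCCCCCCCCCCC1(O)CC(=O)c2c(O)cc(O)cc2O1` departs from compound 1 by hydrogen in place of butyl on a saturated chain carbon, ten or more bonds along the chain from a saturated ring carbon with hydrogen in place of butyl on a saturated chain carbon, ten or more bonds along the chain from a saturated ring carbon. No measured step sizes this change, so in this assay no clear direction and nothing beyond the scatter is expected. The expected move is a 1.1-fold higher number from compound 1 to compound 3 (0.06 log units; within the scatter) at most modestly. Compound 3 is estimated at 20000 nM with a range from 8000 nM to 60000 nM as the likely span.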

Compound 3, half-maximal inhibitory concentration: 43200 nM
Beside the measured number, compound 3's estimate is 2.2-fold (0.33 log units) below it; measured number inside the range.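

In this assay, replacing butyl with hydrogen on this saturated chain carbon gives a 2.5-fold higher number from compound 1 to compound 3 (0.39 log units; beyond the scatter), so the shorter chain weakens the compound on the shared core. Going by these compounds alone, this is the first sized step at this position. Compound 2 could not size it, since it differs from compound 1 in more than one place and its value is a limit, not a number: the limit of > 67200 nM in this assay, at which 1 of the 3 values shown sits.

Going by these compounds, whether a longer chain, or an amine in place of butyl, would lower or raise the number remains open. Within the data shown here, with only two chain lengths on this core, no trend with chain length can be drawn.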